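The source may hold more compounds than are shown below. What is called first, only, known or untested is meant among the compounds shown, and "the series" means these compounds.

Working notes on the shared core. Compound 1 `CC(C)N1C(=O)C=C(Cl)C1(O)c1ccc(Cl)cc1` gives 300 nM in an assay on cell membranes for displacement of a labelled ligand from Cholecystokinin receptor type A (Rattus norvegicus), read by CCK-8 assay, with a stated time of 2 h; on this read-out higher numbers stand for weaker inhibition and lower numbers for stronger inhibition. Compound 2 `O=C1C=C(Cl)C(O)(c2ccccc2)N1C1CCCC1` gives 360 nM in this assay. Compound 3 `O=C1C=C(Cl)C(O)(c2ccc(Cl)cc2)N1C1CCCC1` gives 2500 nM in this assay and stands highest of the three numbers. Its nearest neighbour is compound 2: the step of a 6.9-fold higher number from compound 2 to compound 3 (0.84 log units; beyond the scatter) came with chloro in place of hydrogen on an aromatic carbon. Its furthest is compound 1: the step of an 8.3-fold higher number from compound 1 to compound 3 (0.92 log units; beyond the scatter) came with cyclopentyl in place of isopropyl on an amide-type nitrogen in a ring.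

Compound 4 `CC(C)CN1C(=O)C=C(Cl)C1(O)c1ccc(Cl)cc1` differs from compound 3 in one place: isobutyl in place of cyclopentyl on an amide-type nitrogen in a ring. Of the measured steps only an 8.3-fold higher number from compound 1 to compound 3 (0.92 log units; beyond the scatter) bears on this change, and it runs in the opposite sense: going from isopropyl to cyclopentyl on that nitrogen raised the number, so going from cyclopentyl back to a branched acyclic group, isobutyl, is expected to lower it in this assay. Isobutyl is not isopropyl, so a partial rather than a full reversal is expected, a step of about a 3.6-fold lower number from compound 3 to compound 4 (0.55 log units; beyond the scatter). Compound 4 is therefore expected to give about 700 nM in this assay, within a range of 250 nM to 2500 nM.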

Compound 4, half-maximal inhibitory concentration: 8 nM
Beside the measured number, compound 4's estimate is 88-fold (1.94 log units) above it; measured number outside the range, below it.
By their numbers in this assay, from the lowest: compound 4; then compounds 1 and 2 (each within the scatter of the next); then compound 3.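

In this assay, going by these compounds alone, the group on the amide-type nitrogen proves far more decisive than the earlier compounds showed, since a 310-fold lower number from compound 3 to compound 4 (2.49 log units; beyond the scatter) exceeds the step seen between isopropyl and cyclopentyl. The absence of a ring does not settle the outcome on its own. Two acyclic groups also separate widely: a 38-fold lower number from compound 1 to compound 4 (1.57 log units; beyond the scatter) with only isobutyl in place of isopropyl on the same nitrogen, so the exact shape of the branched chain matters among compounds 1, 3 and 4, which all carry the same chlorinated aromatic group. Nothing at hand accounts for the size of these steps.

The compounds shown leave open whether isobutyl gives a similar gain on the unchlorinated core of compound 2, which is known here only with cyclopentyl, and so whether the chloro step depends on the nitrogen group. They also leave open how far the trend on this nitrogen runs, for example with a straight butyl chain, a neopentyl group or a benzyl group.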